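This account rests on a few compounds, and the source may have more. Where it says the series, first, only, none or still open, it means among the compounds named here.

Series notes. In an ADME assay on Huh-7 cells (Homo sapiens) for cytotoxicity, read by MTT assay, with a stated time of 72 h (a lower number here means that less compound is tolerated, a higher number that more compound is tolerated), compound 1 `CCOC(=O)c1sc2nc(-c3ccco3)cc(C(F)(F)F)c2c1N` gives only a limit, > 20000 nM. Compound 2 `Nc1c(C(=O)O)sc2nc(-c3ccccc3)cc(C(F)(F)F)c12` likewise returns a limit in this assay, > 20000 nM. For the measured compounds named here, compound 3 `COc1ccc(-c2cc(C(F)(F)F)c3c(N)c(C(N)=O)sc3n2)cc1` is the one member with a number in this assay, 46400 nM; it stands alone, since the other two results sit at the limit of > 20000 nM in this assay, at which 2 of the 3 values shown sit. Compound 4 `COc1ccccc1-c1cc(C(F)(F)F)c2c(N)c(C(N)=O)sc2n1` is not yet measured; it differs from compound 3 by 2-methoxyphenyl in place of 4-methoxyphenyl on an aromatic carbon. Going by the values given here, no measured pair differs in a single place, so no step size is known for this assay. For compound 4 the expected step of a 1.2-fold lower number from compound 3 to compound 4 (0.06 log units; within the scatter) is none beyond the usual scatter. Compound 4 is therefore estimated at 40000 nM, within 15000 nM to 100000 nM.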

Compound 4, half-maximal cytotoxic concentration: > 20000 nM
Compound 4: only a limit was reported (the forecaster's own chance of this, stated with the estimate: 45%); the middle value is on the limit's open side.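

In this assay, for the compounds shown here, compound 4 returns only a limit, > 20000 nM, and no step from compound 3 to compound 4 can be read. Whether 2-methoxyphenyl and 4-methoxyphenyl differ in this assay stays open, as does any step size in the series: the limit of > 20000 nM in this assay, at which 3 of the 4 values shown sit.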